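The source may hold more compounds than are shown below. What is called first, only, known or untested is meant among the compounds shown, and "the series" means these compounds.

Measured compounds in a functional assay on MDA-MB-231 cells (Homo sapiens), read by fluorescence and BrdU incorporation, with a stated time of 48 h, tested at 25 uM; a lower number here means a stronger effect, a higher number a weaker effect of the compound at the concentration tested:

Compound 1, `COc1cc(O)c(C(=O)/C=C/c2ccc(F)cc2)c(OC)c1`: "not active" (no number reported)
Compound 2, `COc1cc(OC)c(C(=O)/C=C/c2ccccc2SC)c(OC)c1`: 16%
Compound 3, `COc1cc(OC)c(C(=O)/C=C/c2ccccc2)c(OC)c1`: 23%

Compound 3 has the highest of the two numbers, with compound 2 nearest; the step of a number 7 percentage points higher from compound 2 to compound 3 (within the scatter) lies within the scatter, and compound 1 carries no number at all. Compound 4, `COc1cc(OC)c(C(=O)/C=C/c2ccc(Br)cc2)c(OC)c1`, differs from compound 3 by bromo in place of hydrogen on an aromatic carbon, a bromo set para to a large group. Within the data shown here, no measured step touches this place on the ring, and the one step known, from a methylsulfanyl to a hydrogen, stayed within the scatter. Compound 4 is therefore expected to give 21%, between 6% and 42%, a step of a number 2 percentage points lower from compound 3 to compound 4 (within the scatter) that is expected to remain within the scatter.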

Compound 4, a percentage reported as activity, at one concentration (the size of the read-out at that concentration, not a potency): 44%
Beside the measured number, compound 4's estimate is 23 percentage points below it; the measured number lies above the stated range.
By their numbers in this assay, from the lowest: compounds 2 and 3 (each within the scatter of the next); then compound 4.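

In this assay, among these compounds, bromo in place of hydrogen, on an aromatic carbon para to a large group, gives a number 21 percentage points higher from compound 3 to compound 4 (beyond the scatter) and so a weaker effect at the concentration tested, the first step in this set to pass beyond the scatter. The exchange of 2-(methylsulfanyl)phenyl for 4-bromophenyl likewise gives a number 28 percentage points higher from compound 2 to compound 4 (beyond the scatter) and shows that the ring's substitution can change this read-out. No measurement shown accounts for the change.

Compound 1 carries no number, so its steps cannot be read. As far as these compounds go, whether a chloro or an amine at this place would shift the read-out as bromo does remains open.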